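The source may hold more compounds than are shown below. What is called first, only, known or untested is meant among the compounds shown, and "the series" means these compounds.

The measured compounds:
compound 1, `C[C@@H]1CN(c2cccc3c2C[C@H](CN(C)[C@H]2CCCc4cccnc42)NC3)C[C@H](C)N1`, 100%
compound 2, `CC(C)N(C[C@H]1Cc2c(cccc2N2CCNCC2)CN1)[C@H]1CCCc2cccnc21`, 75%
compound 3, `CCCN(C[C@H]1Cc2c(cccc2N2CCNCC2)CN1)[C@H]1CCCc2cccnc21`, 100%

In an ADME assay on microsomes from liver (Homo sapiens) for metabolic stability, read by LC-MS, with a stated time of 10 min (a lower number here means that less of the compound is left, a higher number that more of the compound is left), compound 1 gives 100%. That is level with compound 3, and together the two are the highest of the three numbers; compound 2 lies lower, and the gap between compound 2 and compound 1 is beyond the scatter. Within the data shown here, the one step that can be read within the measured set, a number 25 percentage points higher from compound 2 to compound 3 (beyond the scatter), changes only the group on the amine nitrogen and leaves the rest of the shared core untouched.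

Compound 4, `CN(C[C@H]1Cc2c(cccc2N2C[C@H]3C[C@@H]2CN3)CN1)[C@H]1CCCc2cccnc21`, keeps the amine side of compound 1 and differs from it at the other end: a group of 7 heavy atoms (5 carbon, 2 nitrogen; 2 five-membered non-aromatic rings with 1 hetero atom each) in place of a group of 8 heavy atoms (6 carbon, 2 nitrogen; one six-membered non-aromatic ring with 2 hetero atoms), on an aromatic carbon. Among the measured compounds shown here, no measured step touches this position, so the step from compound 2 to compound 3 does not bear on it directly; it shows only that a single change at one place moved this assay by a modest amount. Because compound 1 already gives 100%, no rise is possible, and with no comparable change on record the expectation is for no step beyond the scatter, with some allowance for a drop: the expected step is a number 8 percentage points lower from compound 1 to compound 4 (within the scatter). For compound 4 the estimate is therefore 92%, within a range from 68% to 100%.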

Compound 4, percent of the compound remaining: 100%
The estimate for compound 4 lay 8 percentage points below the measured number; measured number inside the range.
By their numbers in this assay, from the lowest: compound 2; then compounds 1, 3 and 4 (each within the scatter of the next).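

In this assay, among these compounds, replacing the 3,5-dimethylpiperazin-1-yl group on the aromatic carbon with the group of 7 heavy atoms and 2 five-membered non-aromatic rings gives no change at the digits printed from compound 1 to compound 4 (within the scatter), the first reading of a change at this position, as the earlier step touched only the amine nitrogen. The ring system at this place can therefore be rebuilt, with the same counts of nitrogen atoms, hydrogen-bond donors, hydrogen-bond acceptors and defined stereocentres, without a step beyond the scatter, although the top of the percent scale leaves no room to see a rise, and compound 4 stands there at 100%. Nothing measured here explains why the number holds at this position.

On these data alone, it remains open whether a morpholine or an open-chain amine on this aromatic carbon would also leave the number level with that of compound 1. As far as these compounds go, it is equally open whether an isopropyl group on the amine nitrogen, as carried by compound 2, would give a lower number when combined with the group that compound 4 carries.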